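Shortening the Side Chain and the Tolerated Concentration

This account rests on a few compounds, and the source may have more. Where it says the series, first, only, none or still open, it means among the compounds named here.

Three compounds share one core and differ only in the length of a straight alkyl chain on it. Compound 1 `CCCCCCc1cc2cn(COCCO)c(=O)nc2o1` carries a hexyl chain, compound 2 `CCCCCCCCCCc1cc2cn(COCCO)c(=O)nc2o1` a decyl chain, and compound 3 `CCCCCCCCc1cc2cn(COCCO)c(=O)nc2o1` an octyl chain. In a functional assay on HEL cells (Homo sapiens), read by microscopy (a higher number here means that more compound is tolerated, a lower number that less compound is tolerated), compound 2 gives 400000 nM. Compound 1 gives only a limit of the assay, >= 400000 nM. As far as these compounds go, compound 3 likewise gives only a limit, >= 80000 nM, so its place among the three stays open. The steps of a number no higher from compound 1 to compound 2 (the limit leaves the size open), a step that the two limits leave unreadable from compound 1 to compound 3 and a step that the limit leaves unreadable from compound 2 to compound 3 have no readable size because of the limit of >= 400000 nM in this assay, at which 1 of the 3 values shown sits, and (the limit of >= 80000 nM in this assay, at which 1 of the 3 values shown sits). Compound 4 `CCCCc1cc2cn(COCCO)c(=O)nc2o1` differs from compound 3 by hydrogen in place of butyl on a saturated chain carbon, four bonds along the chain from an aromatic carbon. With no readable step to guide it, no change beyond the scatter is expected, and compound 4 is estimated at 400000 nM, between 100000 nM and 400000 nM, most likely again as a limit. The expected step is a step that the limit leaves unreadable from compound 3 to compound 4.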

Compound 4, minimum cytotoxic concentration: > 400000 nM
Compound 4: no number, only a limit (the forecaster's own chance of this, stated with the estimate: 75%); the middle value sits exactly at the limit.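

In this assay compound 4, the butyl member, gives > 400000 nM, which is a limit of the assay and not a number. Hydrogen in place of hexyl at this place gives a number no lower from compound 2 to compound 4 (the limit leaves the size open), so shortening the chain to butyl brings no sign of less compound being tolerated than with decyl. The other two steps to compound 4 cannot be read because of the limits: the limit of > 400000 nM in this assay, at which 1 of the 4 values shown sits.

The compounds shown leave open whether a longer chain, such as dodecyl, would give a lower number than compound 2. They also leave open how an amine at the end of the chain would read.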